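Aryl sulfanyl swap on the diamino core

The compounds below may be only part of what the source reports. "The series", "measured", "known", "first", "only" and "open" are said of these compounds alone.

Measured compounds:
compound 1 `COc1cc(CNc2nc3cc(N)cc(N)c3nc2-c2ccccc2)cc(OC)c1OC` — 7760 nM
compound 2 `COc1ccc(Sc2nc3cc(N)cc(N)c3nc2-c2ccccc2)cc1` — a limit of < 100000 nM
compound 3 `Nc1cc(N)c2nc(-c3ccccc3)c(Sc3ccc(Cl)c(Cl)c3)nc2c1` — 95500 nM

For the measured compounds named here, in a functional assay on SK-MEL-5 cells (Homo sapiens) for inhibition, read by sulforhodamine B assay, with a stated time of 48 h (on this read-out higher numbers stand for weaker inhibition of growth and lower numbers for stronger inhibition of growth), compound 3 gives 95500 nM, the highest of the two numbers known. Compound 1 gives 7760 nM, a lower number by a gap beyond the usual scatter. For compound 2 the assay reports only a limit, < 100000 nM. Compound 4 `Nc1cc(N)c2nc(-c3ccccc3)c(Sc3ccc(F)cc3)nc2c1` differs from compound 3 by 4-fluorophenyl in place of 3,4-dichlorophenyl on a sulfur. Going by the values given here, the only measured step on this sulfur is a step that the limit leaves unreadable from compound 2 to compound 3, which cannot be read because of the limit of < 100000 nM in this assay, at which 1 of the 3 values shown sits. Among the compounds with values here, no measured step therefore tells in which direction the change to compound 4 should move the number, and the expected step is a 1.4-fold lower number from compound 3 to compound 4 (0.13 log units; within the scatter), none beyond the scatter. Compound 4 is estimated at 70000 nM, between 20000 nM and 150000 nM.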

Compound 4, concentration for total growth inhibition: 33100 nM
Compound 4: middle estimate off by 2.1-fold (0.33 log units), on the high side; the range from low to high includes it.
By their numbers in this assay, from the lowest: compound 1; then compound 4; then compound 3.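

Working from the sulfur position, a change of the aryl group now gives a readable step: with 4-fluorophenyl in place of 3,4-dichlorophenyl, this assay shows a 2.9-fold lower number from compound 3 to compound 4 (0.46 log units; beyond the scatter) for this single pair. The number therefore responds to the aryl group on this sulfur, though one pair sets no trend. Compound 2 carries only a limit, and its steps to compound 3 and compound 4 cannot be read: the limit of < 100000 nM in this assay, at which 1 of the 4 values shown sits.

Open remains how the number moves with an amine or a carboxylic acid on the phenyl ring attached to this sulfur. Also open, on these data alone, is whether a longer chain between the sulfur and that ring changes the number.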